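The source may report more compounds than this note shows. Statements on the series, on what has been measured and on what is new or still open speak of the compounds shown alone.

Measured compounds:
- compound 1, `O=C(NC(=S)Nc1nc2ccccc2s1)c1ccc([N+](=O)[O-])cc1`: 33800 nM
- compound 2, `O=C(NC(=S)Nc1nc2cc(Br)ccc2s1)c1ccccc1`: 32100 nM
- compound 3, `O=C(NC(=S)Nc1nc2cc([N+](=O)[O-])ccc2s1)c1ccccc1`: 41600 nM

The three compounds share one core and differ only in a single group on one of their two aromatic rings. In a functional assay on MCF7 cells (Homo sapiens) for cytotoxicity, read by MTT assay, with a stated time of 24 h (a lower number here means a stronger inhibitor, a higher number a weaker inhibitor), compound 2 gives 32100 nM, and the other two values lie close to it: compound 1 gives 33800 nM and compound 3 gives 41600 nM, both within the usual scatter of compound 2. Among the compounds with values here, the one single-change step among them, a 1.3-fold higher number from compound 2 to compound 3 (0.11 log units; within the scatter), is likewise within the scatter, so no measured change here has moved the number beyond what repeat measurements would show.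

Compound 4, `O=C(NC(=S)Nc1nc2cc(Br)ccc2s1)c1ccc([N+](=O)[O-])cc1`, is the bromo-bearing compound 2 with one further change: nitro in place of hydrogen on an aromatic carbon. Within the data shown here, no measured step matches this change exactly. The nearest guide is compound 1, which carries the same nitro group on the same ring without the bromo, and its value sits within the scatter of compound 2. On that basis the step of a 1.1-fold higher number from compound 2 to compound 4 (0.04 log units; within the scatter) is expected to stay within the scatter, with no clear direction. Compound 4 is therefore estimated at 35000 nM, within a range of 15000 nM to 80000 nM.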

Compound 4, half-maximal inhibitory concentration: 32400 nM
Compound 4: middle estimate off by 1.1-fold (0.03 log units), on the high side; the measured number falls inside the stated range.
By their numbers in this assay, from the lowest: compounds 2, 4, 1 and 3 (each within the scatter of the next).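

In this assay the nitro group, on the six-membered aromatic ring of carbon only and para to a large group, can now be read directly with the bromo group present: a 1.0-fold higher number from compound 2 to compound 4 (0.00 log units; within the scatter) is a step within the scatter. The same compound also allows the bromo change to be read with the nitro group present, and a 1.0-fold lower number from compound 1 to compound 4 (0.02 log units; within the scatter) is likewise within the scatter. Compound 4 carries both groups, yet its number cannot be told apart from that of compound 2 with the bromo group alone or compound 1 with the nitro group alone, so these compounds show no sign that the two groups together do anything in this test that repeat measurements could separate from scatter.

An amine or a carboxylic acid at this position would show whether the number can move there at all, since bromo and nitro alone cannot answer that. Nothing shown here gives any measured explanation of why these values stay so close.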